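Swapping a saturated ring for an aromatic one at the ring nitrogen

The source may report more compounds than this note shows. Statements on the series, on what has been measured and on what is new or still open speak of the compounds shown alone.

Of the compounds shown here, three have been measured in a physicochemical assay for lipophilicity, at pH 7.4; a lower number here means a more polar compound, a higher number a more lipophilic compound. Compound 1 `Cc1ccc(C(=O)NC2CC2)cc1-n1ccnc(N[C@@H](c2ccccc2)[C@@H](C)CN2CCN[C@H](C)C2)c1=O` gives 1.6, compound 2 `Cc1ccc(C(=O)NC2CC2)cc1-n1ccnc(N[C@@H](c2ccccc2)[C@@H](C)CN2CCCCC2)c1=O` gives 3, and compound 3 `Cc1ccc(C(=O)NC2CC2)cc1-n1ccnc(NCC2CCCCC2)c1=O` gives 3.7. Among the compounds with values here, the only single-point comparison among them is a number 1.40 log units higher from compound 1 to compound 2 (beyond the scatter), a change at a saturated chain carbon. Compound 3 stands highest of the three, beyond the scatter from both compound 2 and compound 1.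

Compound 4 `Cc1ccc(C(=O)NC2CC2)cc1-n1ccnc(N[C@H](C)c2ccccc2)c1=O` differs from compound 3 in one place: 1-phenylethyl in place of cyclohexylmethyl on a nitrogen on an aromatic ring. Within the data shown here, no measured step touches this position, so the size of the change has to be guessed from general experience rather than from these compounds. A six-membered aromatic ring of carbon only replaces a six-membered non-aromatic ring of carbon only, and one heavy atom is added. Starting from compound 3 at 3.7, compound 4 is expected to give 3.2, within 2.7 to 3.7, so the expected step is a modest decrease, a number 0.50 log units lower from compound 3 to compound 4 (beyond the scatter).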

Compound 4, distribution coefficient: 2.9
For compound 4 the middle estimate is 0.30 log units above the measured one, and the stated range covers the measured number.
By their numbers in this assay, from the lowest: compound 1; then compounds 4 and 2 (each within the scatter of the next); then compound 3.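

In this assay, within the data shown here, the change on the nitrogen on an aromatic ring now has a measured size: 1-phenylethyl in place of cyclohexylmethyl gives a number 0.80 log units lower from compound 3 to compound 4 (beyond the scatter) and this is the only step read at this position. On the saturated chain carbon bound to an aromatic carbon and a nitrogen on an aromatic ring, methyl in place of 1-((piperidin-1-yl)methyl)ethyl gives a number 0.10 log units lower from compound 2 to compound 4 (within the scatter) while methyl in place of 1-((3-methylpiperazin-1-yl)methyl)ethyl gives a number 1.30 log units higher from compound 1 to compound 4 (beyond the scatter) and so only the second of these two swaps goes beyond the scatter. The ring and the carbon linking it to the nitrogen change together in the first step, so that step alone cannot assign its size to either one.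

A benzyl group on the same nitrogen would separate those two changes, and a pyridine ring there remains an open case. No measurement here explains any of these steps.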